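The source may report more compounds than this note shows. Statements on the series, on what has been measured and on what is new or still open speak of the compounds shown alone.

Of the compounds shown here, three that share one core have been measured in an assay for inhibition of serine/threonine-protein kinase Sgk1 (Homo sapiens), with stated times of 30 min and 60 min, in the presence of a further agent that is not named here; on this read-out higher numbers stand for weaker inhibition and lower numbers for stronger inhibition. Compound 1 `Cc1n[nH]c2nc(-c3ccc(NS(=O)(=O)c4cc(Cl)ccc4F)cc3)nc(OCC3(CN)COC3)c12` gives 1 nM. Compound 2 `Cc1n[nH]c2nc(-c3ccc(NS(=O)(=O)c4cc(Cl)ccc4F)cc3)nc(OC3CCOCC3)c12` gives 5 nM. Compound 3 `Cc1n[nH]c2nc(-c3ccc(NS(=O)(=O)c4cc(Cl)ccc4F)cc3)nc(OCCCO)c12` gives 2 nM, which places it second highest of the three numbers; the nearest is compound 1 and the furthest is compound 2. Between them, a 2.5-fold lower number from compound 2 to compound 3 (0.40 log units; beyond the scatter), while a 2.0-fold higher number from compound 1 to compound 3 (0.30 log units; within the scatter).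

Compound 4 `Cc1n[nH]c2nc(-c3ccc(NS(=O)(=O)c4cc(Cl)ccc4F)cc3)nc(OCC3CN(C(C)C)C3)c12` has not been measured. It differs from compound 3 in one place: 1-isopropylazetidin-3-yl in place of 2-hydroxyethyl on a saturated chain carbon bound to an oxygen on an aromatic ring. Going by the values given here, of the measured steps, the one from compound 1 to compound 3 is the closest guide, since it also exchanges a ring-bearing group with a nitrogen for a short hydroxyl chain at the same place, and it stayed within the scatter. The step from compound 2 to compound 3 shows that a ring in this position can go with a modestly higher number, but that ring had no nitrogen. With one step within the scatter and one modestly beyond it pointing the other way, the expected change in this assay for compound 4 is no change at the digits printed from compound 3 to compound 4 (within the scatter), that is, none beyond the scatter. Compound 4 is therefore estimated at 2 nM, with a range from 0.7 nM to 6 nM.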

Compound 4, half-maximal inhibitory concentration: 1 nM
The estimate for compound 4 lay 2.0-fold (0.30 log units) above the measured number; the range from low to high includes it.
By their numbers in this assay, from the lowest: compounds 1, 4 and 3 (each within the scatter of the next); then compound 2.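

In this assay, this place accepts a much larger group than the hydroxyl chain: 3 heavy atoms leave and 7 enter, among them a four-membered ring with a nitrogen, and the outcome is a 2.0-fold lower number from compound 3 to compound 4 (0.30 log units; within the scatter). The entering group has 0 hydrogen-bond donors, so neither the hydroxyl of compound 3 nor the amine of compound 1 is needed to keep the number this low, the comparison with compound 1 being no change at the digits printed from compound 1 to compound 4 (within the scatter). Going by these compounds alone, a ring on this side chain also does not by itself go with the higher number of compound 2, since the change to the azetidine gives a 5.0-fold lower number from compound 2 to compound 4 (0.70 log units; beyond the scatter), which is the clearest step of the three and one that the earlier compounds could not have suggested.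

Still open, from the compounds shown here alone, is whether that gap follows the ring nitrogen, the isopropyl group or the saturated chain carbon bound to the oxygen, and how an azetidine without the isopropyl group or a carboxylic acid would read at this place. Nothing measured here explains why these numbers fall as they do.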